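The source may hold more compounds than are shown below. What is called first, only, known or untested is meant among the compounds shown, and "the series" means these compounds.

Measured so far in a functional assay on Huh-7 cells (Homo sapiens) for inhibition, read by MTT assay, with a stated time of 48 h; on this read-out lower numbers stand for stronger inhibition and higher numbers for weaker inhibition:
compound 1 `O=C(/C=C/c1coc2cc(O)ccc2c1=O)NCc1ccccc1`: 4690 nM
compound 2 `COc1ccc2c(=O)c(/C=C/C(=O)Nc3cc(C)ccc3C)coc2c1`: 11100 nM
compound 3 `Cc1ccccc1NC(=O)/C=C/c1coc2cc(O)ccc2c1=O`: 11100 nM

On these numbers compound 2 stands level with compound 3 at the digits shown, the two together giving the highest values of the three, while compound 1 gives the lowest. Compound 4 `COc1ccc2c(=O)c(/C=C/C(=O)Nc3ccc(Cl)cc3)coc2c1` differs from compound 2 by 4-chlorophenyl in place of 2,5-dimethylphenyl on an amide-type nitrogen. Among the compounds with values here, the one measured step on that same amide-type nitrogen is a 2.4-fold higher number from compound 1 to compound 3 (0.37 log units; beyond the scatter), which exchanges benzyl for 2-methylphenyl rather than one substituted phenyl for another, so it bears only loosely on this change. With no measured exchange between two substituted phenyls, compound 4 is expected to stay near compound 2, with a step of a 1.2-fold lower number from compound 2 to compound 4 (0.09 log units; within the scatter) not clearly beyond the scatter. Compound 4 is therefore estimated at 9000 nM, within 3500 nM to 25000 nM.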

Compound 4, half-maximal inhibitory concentration: 37100 nM
Compound 4: the middle estimate sits 4.1-fold (0.62 log units) below what was measured, outside the stated range (above it).
By their numbers in this assay, from the lowest: compound 1; then compounds 2 and 3 (each within the scatter of the next); then compound 4.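

In this assay, placing 4-chlorophenyl instead of 2,5-dimethylphenyl on the amide-type nitrogen gives a 3.3-fold higher number from compound 2 to compound 4 (0.52 log units; beyond the scatter), which means weaker inhibition. The earlier step exchanged benzyl for 2-methylphenyl, whereas this one shows that the read-out also responds to an exchange between two substituted phenyl groups at this nitrogen. Nothing available explains this step.

Because the chlorine enters as both methyl groups leave, the compounds shown cannot separate those two parts of the change. An unsubstituted phenyl, 4-methylphenyl or 4-fluorophenyl group on this nitrogen would remain to be compared.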